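The source may report more compounds than this note shows. Statements on the series, on what has been measured and on what is new or still open speak of the compounds shown alone.

Three compounds share one core and differ only in what sits on the benzyl ring. Compound 1 `Cc1cc(Nc2nc(NCc3ccccc3)nc3[nH]ncc23)n[nH]1` gives 1960 nM in an assay on isolated protein for inhibition of serine/threonine-protein kinase PAK 4 (Homo sapiens), read by HTRF, with a stated time of 60 min; a higher number here means a weaker inhibitor, a lower number a stronger inhibitor. Compound 2 `Cc1cc(Nc2nc(NCc3cccc(F)c3)nc3[nH]ncc23)n[nH]1` gives 458 nM, and compound 3 `Cc1cc(Nc2nc(NCc3cccc(Br)c3)nc3[nH]ncc23)n[nH]1` gives 4340 nM, the highest number of the three; the steps of a 2.2-fold higher number from compound 1 to compound 3 (0.35 log units; beyond the scatter) and a 9.5-fold higher number from compound 2 to compound 3 (0.98 log units; beyond the scatter) place it above both others. Compound 4 `Cc1cc(Nc2nc(NCc3ccc(F)cc3)nc3[nH]ncc23)n[nH]1` carries 4-fluorophenyl in place of 3-bromophenyl on a saturated chain carbon bound to a nitrogen on an aromatic ring. For the measured compounds named here, two measured steps bear on this change: a 2.2-fold higher number from compound 1 to compound 3 (0.35 log units; beyond the scatter) shows that bromo raised the number, and a 9.5-fold higher number from compound 2 to compound 3 (0.98 log units; beyond the scatter) shows that bromo in place of fluoro raised it further. The fluoro in a 4.3-fold lower number from compound 1 to compound 2 (0.63 log units; beyond the scatter) sat on a different carbon, so it speaks only in part. Taking the bromine away is therefore expected to lower the number, with an expected step of a 3.6-fold lower number from compound 3 to compound 4 (0.56 log units; beyond the scatter). Compound 4 is estimated at 1200 nM, within a range from 400 nM to 3500 nM.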

Compound 4, half-maximal inhibitory concentration: 395 nM
For compound 4 the middle estimate is 3.0-fold (0.48 log units) above the measured one; the measured number lies below the stated range.
By their numbers in this assay, from the lowest: compounds 4 and 2 (each within the scatter of the next); then compound 1; then compound 3.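

In this assay, the 4-fluorophenyl and 3-fluorophenyl groups cannot be told apart, with a 1.2-fold lower number from compound 2 to compound 4 (0.06 log units; within the scatter), so the lower number seen with fluoro is not confined to one ring carbon. Compound 4 also improves on the plain benzyl group, with a 5.0-fold lower number from compound 1 to compound 4 (0.70 log units; beyond the scatter), while replacing 3-bromophenyl gives an 11-fold lower number from compound 3 to compound 4 (1.04 log units; beyond the scatter). No supporting data explain these differences.

On these data alone, that large step changes both the halogen and its ring carbon, so their separate contributions remain open. A 4-bromophenyl group would help separate them, and a 4-aminophenyl group would test a non-halogen substituent.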